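This account rests on a few compounds, and the source may have more. Where it says the series, first, only, none or still open, it means among the compounds named here.

Going by the values given here, in an assay on isolated protein for inhibition of Rho-associated protein kinase 2 (Homo sapiens), read by scintillation counting, radiometric assay and 33P incorporation, with a stated time of 40 min, in the presence of a further agent that is not named here (a higher number here means a weaker inhibitor, a lower number a stronger inhibitor), three compounds have numbers so far. Among the compounds with values here, compound 1 `CN(C)c1ccc(C(=O)Nc2cccc(NC(=O)COc3ccc4c(c3)NC(=O)CC4)c2)cc1` gives 3140 nM, and compound 2 `CN(C)c1ccc(C(=O)Nc2cccc(NC(=O)COc3ccc4c(c3)CCC(=O)N4)c2)cc1` gives 9970 nM; the one measured step between them, a 3.2-fold higher number from compound 1 to compound 2 (0.50 log units; beyond the scatter), concerns a change on an oxygen on a saturated carbon. Compound 3 `O=C(COc1ccc2c(=O)ccoc2c1)Nc1cccc(NC(=O)c2ccc(F)cc2)c1` gives 54 nM, the lowest of the three numbers, with compound 1 nearest and compound 2 furthest, both beyond the scatter.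

Compound 4 `Cc1cc(C(=O)Nc2cccc(NC(=O)COc3ccc4c(=O)ccoc4c3)c2)no1` is next. It differs from compound 3 by 5-methyl-1,2-oxazol-3-yl in place of 4-fluorophenyl on a carbonyl carbon. Within the data shown here, no measured step bears on this change: the step from compound 1 to compound 2 alters a different part of the shared core, and nothing shows what exchanging the group on the carbonyl carbon does. The expectation therefore rests on compound 3 alone, with wide uncertainty and no clear direction. Compound 4 is expected to give about 110 nM, within a range from 25 nM to 500 nM. The expected step, a 2.0-fold higher number from compound 3 to compound 4 (0.31 log units; beyond the scatter), is thus estimated to stay within or only modestly beyond the scatter.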

Compound 4, half-maximal inhibitory concentration: 5 nM
Beside the measured number, compound 4's estimate is 22-fold (1.34 log units) above it, outside the stated range (below it).
By their numbers in this assay, from the lowest: compound 4; then compound 3; then compound 1; then compound 2.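

In this assay, going by these compounds alone, the group on the carbonyl carbon whose other neighbour is an amide-type nitrogen turns out to matter strongly: 5-methyl-1,2-oxazol-3-yl in place of 4-fluorophenyl gives an 11-fold lower number from compound 3 to compound 4 (1.03 log units; beyond the scatter), a large step at a position the earlier compounds gave no measured reading of. The exchange replaces a six-membered aromatic ring of carbon only, with 0 hydrogen-bond acceptors, by a five-membered aromatic ring with 2 hydrogen-bond acceptors. No measurement is available that accounts for the size of this step.

As far as these compounds go, it remains open whether the step belongs to the five-membered ring or to its methyl, which a 1,2-oxazol-3-yl without the methyl, or one carrying an ethyl, would separate. From the compounds shown here alone, it is also open whether a plain phenyl or a pyridyl on the same carbonyl carbon would stand nearer compound 3 or compound 4.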